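The compounds below may be only part of what the source reports. "The series", "measured", "known", "first", "only" and "open" are said of these compounds alone.

Of the compounds shown here, three have so far been measured in an ADME assay on Vero cells (Chlorocebus sabaeus) for cytotoxicity, read by crystal violet staining; on this read-out higher numbers stand for lower toxicity in this test and lower numbers for higher toxicity in this test. Compound 2, `Fc1ccc(F)c(/N=N/Nc2cccc(C(F)(F)F)c2)c1`, carries a trifluoromethyl group on an aromatic carbon; in this assay compound 2 gives 80000 nM. Compound 1, `Fc1ccc(F)c(/N=N/Nc2ccccc2)c1`, is the same molecule with the change (hydrogen in place of trifluoromethyl on an aromatic carbon); in this assay compound 1 gives 80000 nM. The step of no change at the digits printed from compound 2 to compound 1 (within the scatter) thus stays within the scatter of this kind of measurement. Compound 3, `CN(C)CCCN(/N=N/c1ccccc1)c1cccc(C(F)(F)F)c1`, is built on a different core; the difference between its core and the core of compound 2 is not broken down here. In this assay compound 3 gives 20000 nM, the lowest of the three numbers, and its distance to compound 1 and to compound 2 lies beyond the scatter.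

Compound 4, `CN(C)CCCN(/N=N/c1ccccc1)c1ccccc1`, has not yet been measured in this assay. It differs from compound 3 by hydrogen in place of trifluoromethyl on an aromatic carbon, the same kind of change as that from compound 2 to compound 1, and the description of the place is the same word for word in both cases. Because the step of no change at the digits printed from compound 2 to compound 1 (within the scatter) showed no change beyond the scatter, the step of no change at the digits printed from compound 3 to compound 4 (within the scatter) is expected to be of similar size, that is, close to none. On this basis compound 4 is estimated to give 20000 nM in this assay, with a likely range from 10000 nM to 40000 nM. The measured number will tell whether this expectation holds.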

Compound 4, half-maximal cytotoxic concentration: 35000 nM
Estimate against measurement, compound 4: 1.8-fold (0.24 log units) below; measured number inside the range.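

In this assay, putting hydrogen in place of trifluoromethyl on an aromatic carbon gives a 1.8-fold higher number from compound 3 to compound 4 (0.24 log units; within the scatter). Set beside the earlier case, the change reads alike on the two cores: the same change on two cores in this assay, no change at the digits printed (within the scatter) from compound 2 to compound 1 and a 1.8-fold higher number (0.24 log units; within the scatter) from compound 3 to compound 4, 1.8-fold (0.24 log units) apart, within the scatter of two such steps. This shows that, for these two pairs, the change stays within the scatter on either core and that no difference between the cores can be seen, but it rests on two pairs in a single test, so it does not show that the steps are identical rather than too small to tell apart, that the change would carry over to any further core, or why the two steps agree.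

Trifluoromethyl and hydrogen are the only two groups at this place among the compounds shown, so it remains open whether a chlorine, a nitrile, a methoxy group or a carboxylic acid on the same aromatic carbon would also leave the number within the scatter. Going by these compounds, it also remains open whether the agreement between the two steps would survive on a core carrying a shorter or longer amine chain, or a primary amine at the end of that chain.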